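Replacing a Difluorophenyl Group and What It Costs

The compounds below may be only part of what the source reports. "The series", "measured", "known", "first", "only" and "open" are said of these compounds alone.

Compound 1 `CN(C(=O)NC(=O)c1ccc(F)c(F)c1)c1nc(C(F)(F)F)c(C(=O)N/N=C/c2ccccc2C(F)(F)F)s1` and compound 2 `CN(C(=O)NC(=O)c1ccc(F)c(F)c1)c1nc(C(F)(F)F)c(C(=O)N/N=C/c2cc(C(F)(F)F)cc(C(F)(F)F)c2)s1` share a core; how the two cores differ is not broken down here. In a functional assay on MCF7 cells (Homo sapiens) for inhibition, read by MTT assay, with a stated time of 72 h (on this read-out lower numbers stand for stronger inhibition and higher numbers for weaker inhibition), compound 1 gives 8.21 ug/mL, and compound 2 gives 2.61 ug/mL. Compound 3 `CN(C(=O)NC(=O)c1ccc(Cl)cc1Cl)c1nc(C(F)(F)F)c(C(=O)N/N=C/c2cc(C(F)(F)F)cc(C(F)(F)F)c2)s1` differs from compound 2 in one place: 2,4-dichlorophenyl in place of 3,4-difluorophenyl on a carbonyl carbon. In this assay compound 3 reaches only a limit of the assay, reported as > 100 ug/mL. That single swap produced an at least 38-fold higher number from compound 2 to compound 3 (1.58 log units; beyond the scatter), the number running up to the limit noted as the limit of > 100 ug/mL in this assay, at which 1 of the 3 values shown sits. Compound 4 `CN(C(=O)NC(=O)c1ccc(Cl)cc1Cl)c1nc(C(F)(F)F)c(C(=O)N/N=C/c2ccccc2C(F)(F)F)s1` carries the same change, made on the core of compound 1: 2,4-dichlorophenyl in place of 3,4-difluorophenyl on a carbonyl carbon. For the measured compounds named here, because the only measured instance of this change gave an at least 38-fold higher number from compound 2 to compound 3 (1.58 log units; beyond the scatter), a loss of similar size is expected when it is repeated on compound 1. On that basis the step expected for compound 4 is a 15-fold higher number from compound 1 to compound 4 (1.16 log units; beyond the scatter). Compound 4 is therefore estimated at 120 ug/mL in this assay, with a plausible range from 40 ug/mL to 400 ug/mL, and a real chance that only a limit is reported.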

Compound 4, half-maximal inhibitory concentration: 9.12 ug/mL
Estimate against measurement, compound 4: 13-fold (1.12 log units) above; the measured number lies below the stated range.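

Made on the core of compound 1, the same swap of 3,4-difluorophenyl for 2,4-dichlorophenyl leaves the result in this assay within the scatter: a 1.1-fold higher number from compound 1 to compound 4 (0.05 log units; within the scatter). The large loss seen on one core therefore did not carry over to the other, and the effect of this change depends on the core that carries it: the same change on two cores in this assay, an at least 38-fold higher number (1.58 log units; beyond the scatter) from compound 2 to compound 3 and a 1.1-fold higher number (0.05 log units; within the scatter) from compound 1 to compound 4, at least 34-fold (1.53 log units) apart, beyond the scatter of two such steps Compound 3 gives > 100 ug/mL, which is a limit of the assay and not a number, and these two pairs alone do not show which difference between the cores decides the outcome.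

On these data alone, it remains open how the swap behaves on any further core, since two cores that disagree give no rule for a third. As far as these compounds go, it is also open how this assay would respond to a plain phenyl group, a chlorophenyl group with a single chlorine, or a methyl group on the same carbonyl carbon.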